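This account rests on a few compounds, and the source may have more. Where it says the series, first, only, none or still open, it means among the compounds named here.

Going by the values given here, compound 2 `CCNC(=S)NCCC(O)c1cc(Cl)ccc1N` has the highest of the two numbers measured so far in an assay for inhibition of Nitric oxide synthase, inducible (Homo sapiens), read by scintillation counting, with a stated time of 30 min (on this read-out higher numbers stand for weaker inhibition and lower numbers for stronger inhibition), where compound 2 gives 770000 nM; its nearest neighbour is compound 1 `CNC(=S)NCCC(O)c1cc(Cl)ccc1N`, which in this assay gives 710000 nM, a gap that lies within the scatter, so the two cannot be told apart. Compound 3 `CCCNC(=S)NCCC(O)c1cc(Cl)ccc1N` is the next compound in this series, and it differs from compound 2 by methyl in place of hydrogen on a saturated chain carbon, two bonds along the chain from an amide-type nitrogen. Among the compounds with values here, the one measured step that bears on this kind of change, chain growth on the same nitrogen, is a 1.1-fold higher number from compound 1 to compound 2 (0.04 log units; within the scatter), a step too small to count as a real change. On that basis no step beyond the scatter is expected in this assay from compound 2 to compound 3, as a 1.0-fold higher number from compound 2 to compound 3 (0.02 log units; within the scatter) expresses. Compound 3 is therefore estimated to give about 800000 nM in this assay, with a likely range from 350000 nM to 1800000 nM.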

Compound 3, half-maximal inhibitory concentration: > 1000000 nM
Compound 3: only a limit was reported; the forecaster's own chance of this, stated with the estimate: 25%; at least 1.2-fold (0.09 log units) between middle value and limit.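

In this assay compound 3 is reported only as a limit, > 1000000 nM, and not as a number, the first such result among the compounds shown. Going from ethylamino to propylamino gives an open-ended step, an at least 1.2-fold higher number from compound 2 to compound 3 (0.11 log units; that floor lies within the scatter), and the longer change on the same chain gives another, an at least 1.4-fold higher number from compound 1 to compound 3 (0.14 log units; that floor lies within the scatter); since both floors lie within the scatter, neither establishes a real weakening, yet neither excludes one. The true size of these steps stays unknown because the reading for compound 3 stops at a limit: the limit of > 1000000 nM in this assay, at which 1 of the 3 values shown sits.

As far as these compounds go, it remains open whether growing this chain further, to butyl, would also give only a limit. Equally open, from the compounds shown here alone, is whether a hydroxyl or an amine carried on this chain would return a measurable number.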